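Chain extension on the core of compound 1 toward a carboxylic acid

The compounds below may be only part of what the source reports. "The series", "measured", "known", "first", "only" and "open" are said of these compounds alone.

Measured compounds:
compound 1 `Cn1nc(-c2cccnc2)c2ccccc2c1=O` — 63%
compound 2 `CC(=O)OCCn1nc(-c2cccnc2)c2ccccc2c1=O` — 32%
compound 3 `O=c1c2ccccc2c(-c2cccnc2)nn1CCCCSc1ncccn1` — 96%

In an assay on isolated protein (Oryctolagus cuniculus) with Thromboxane-A synthase (Homo sapiens) as the target, tested at 1 uM (on this read-out lower numbers stand for less inhibition and higher numbers for more inhibition at the one concentration tested (going by the name of the read-out)), compound 1 stands second of the three, with compound 2 below it and compound 3 above it, both gaps beyond the scatter. Compound 4 `O=C(O)CCCn1nc(-c2cccnc2)c2ccccc2c1=O` has not yet been measured. It differs from compound 1 in one place: 2-carboxyethyl in place of hydrogen on a saturated chain carbon bound to an aromatic nitrogen.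

For the measured compounds named here, two measured steps bear on this change, since both alter the same chain on the core. The step of a number 31 percentage points lower from compound 1 to compound 2 (beyond the scatter) shows that putting a short substituted chain in place of hydrogen at this position lowered inhibition. The step of a number 64 percentage points higher from compound 2 to compound 3 (beyond the scatter) shows that lengthening that chain further raised inhibition well beyond the level of compound 1. A hydrogen-bond donor enters with the 2-carboxyethyl group of compound 4, which neither compound 2 nor compound 3 carries, so the two steps give only an indirect guide. Compound 4 is therefore expected to show a moderate rise, a number 12 percentage points higher from compound 1 to compound 4 (beyond the scatter), with wide uncertainty in either direction. The estimate for compound 4 in this assay is 75%, ranging from 45% to 95%.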

Compound 4, a percentage reported as inhibition, at one concentration (the size of the read-out at that concentration, not a potency): 73%
Estimate against measurement, compound 4: 2 percentage points above, and the stated range covers the measured number.
By their numbers in this assay, from the lowest: compound 2; then compounds 1 and 4 (each within the scatter of the next); then compound 3.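

In this assay, going from methyl to 3-carboxypropyl gives a number 10 percentage points higher from compound 1 to compound 4 (within the scatter), so a chain ending in carboxy can stand at this position with no change beyond the scatter, something the fall at compound 2 had left in doubt. What sits at the far end of the chain, or how long the chain is, does matter among these compounds: the acetoxy-ended chain gives way to the carboxy-ended one in a number 41 percentage points higher from compound 2 to compound 4 (beyond the scatter), while the chain ending in (pyrimidin-2-yl)sulfanyl gives way to it in a number 23 percentage points lower from compound 3 to compound 4 (beyond the scatter), which leaves that chain as the one that sets compound 3 apart from the carboxy-ended compound 4. Nothing available here accounts for these differences.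

Chain length and chain end change together in both of those steps, so neither can be credited alone; a longer chain ending in a carboxylic acid, or a (pyrimidin-2-yl)sulfanyl group on a chain the length of 3-carboxypropyl, would separate them. From the compounds shown here alone, whether the acid hydrogen itself counts also stays open, and the methyl ester or the primary amide of the same chain would address that.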